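From isopropoxy to butoxy on the shared core

This account rests on a few compounds, and the source may have more. Where it says the series, first, only, none or still open, it means among the compounds named here.

Measured so far in a functional assay on MV4-11 cells (Homo sapiens) for inhibition, read by resazurin assay, with a stated time of 72 h (on this read-out higher numbers stand for weaker inhibition of growth and lower numbers for stronger inhibition of growth), are two compounds:
- compound 1 `COc1ccc(Nc2nccc(-c3sc(OC)nc3C)n2)c(OC)c1` with 1400 nM as its value
- compound 2 `COc1ccc(Nc2nccc(-c3sc(OC(C)C)nc3C)n2)c(OC)c1` with 8690 nM as its value

Compound 2 at 8690 nM holds the higher of the two numbers, and so shows the weaker inhibition of growth of this pair. Among the compounds with values here, its nearest neighbour is compound 1, and the one measured step is a 6.2-fold higher number from compound 1 to compound 2 (0.79 log units; beyond the scatter) with isopropyl in place of methyl on an oxygen on an aromatic ring. Compound 3 `CCCCOc1nc(C)c(-c2ccnc(Nc3ccc(OC)cc3OC)n2)s1` changes that same place, by butyl in place of isopropyl on an oxygen on an aromatic ring so that butoxy stands where compound 2 has isopropoxy. Within the data shown here, no measured compound yet carries butyl on this oxygen, so the earlier step is only a loose guide. It suggests that larger groups here do not help, but a second rise of the same size is not assumed. The expected outcome is a 1.2-fold higher number from compound 2 to compound 3 (0.06 log units; within the scatter) with real room on either side. Compound 3 is estimated at 10000 nM with 3500 nM to 30000 nM as the expected range.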

Compound 3, concentration for 50% growth inhibition: 7860 nM
Compound 3: the middle estimate sits 1.3-fold (0.10 log units) above what was measured; the measured number falls inside the stated range.
By their numbers in this assay, from the lowest: compound 1; then compounds 3 and 2 (each within the scatter of the next).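

In this assay, the change from isopropoxy to butoxy gives a 1.1-fold lower number from compound 2 to compound 3 (0.04 log units; within the scatter) and so does not separate isopropyl from butyl on this oxygen, a comparison that the earlier pair, with only methyl and isopropyl, could not offer. The step of a 5.6-fold higher number from compound 1 to compound 3 (0.75 log units; beyond the scatter) is printed as beyond the scatter, as is the step of a 6.2-fold higher number from compound 1 to compound 2 (0.79 log units; beyond the scatter), which shows that the higher number is not confined to isopropyl: among these three compounds, both larger groups stand above methyl, and no compound goes against this. Nothing available here gives a reason for this behaviour at the oxygen.

Going by these compounds, it remains open whether ethyl or a longer chain would follow the same course, or whether a chain carrying an amine or a carboxylic acid on this oxygen could bring the number under that of compound 1 at 1400 nM in this assay. All three compounds keep the rest of the shared core unchanged, so the compounds shown also cannot tell whether this order among methyl, isopropyl and butyl would hold on a changed core.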